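Reshaping the Side Chain of Compound 3

The source may report more compounds than this note shows. Statements on the series, on what has been measured and on what is new or still open speak of the compounds shown alone.

In a functional assay on A549 cells (Homo sapiens) for antiproliferative activity, read by MTT assay, with a stated time of 72 h (a lower number here means a stronger inhibitor, a higher number a weaker inhibitor), compound 1 (`C=C(C)C(=O)Nc1cc2c(N3CCc4ccccc43)ncnc2cc1OC`) gives 7320 nM, compound 2 (`COc1cc2ncnc(N3CCc4ccccc43)c2cc1NC(=O)C=C(C)C`) gives 6270 nM and compound 3 (`COc1cc2ncnc(N3CCCc4ccccc43)c2cc1NC(=O)C=C(C)C`) gives 5410 nM. Compound 3 therefore stands level with the other two, since all three numbers lie within the usual scatter of one another. Compound 4 (`CC/C=C/C(=O)Nc1cc2c(N3CCCc4ccccc43)ncnc2cc1OC`) has the same atoms as compound 3, joined differently: but-1-en-1-yl in place of 2-methylprop-1-en-1-yl on a carbonyl carbon. Among the compounds with values here, only one measured step changes the group at this place, a 1.2-fold lower number from compound 1 to compound 2 (0.07 log units; within the scatter), and it lies within the scatter. One small step is thin evidence, but it gives no reason to expect a real shift in this assay. The expected step is a 1.0-fold higher number from compound 3 to compound 4 (0.01 log units; within the scatter), which would not exceed the scatter. Compound 4 is estimated at 5500 nM, with a range of 2800 nM to 10800 nM.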

Compound 4, half-maximal inhibitory concentration: 5030 nM
Compound 4: middle estimate off by 1.1-fold (0.04 log units), on the high side, and the stated range covers the measured number.
By their numbers in this assay, from the lowest: compounds 4, 3, 2 and 1 (each within the scatter of the next).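

On the core of compound 3, rearranging the four carbons of this group, with 2-methylprop-1-en-1-yl giving way to but-1-en-1-yl on the carbonyl carbon, produces a 1.1-fold lower number from compound 3 to compound 4 (0.03 log units; within the scatter) in this assay. The earlier step at this place involved a different core and a different pair of groups, so this adds a second core on which a change here stays within the scatter. No measurement available explains this result. On these data alone, whether an amine or a longer chain at this place would move the number beyond the scatter remains open.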